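The compounds below may be only part of what the source reports. "The series", "measured", "known", "first", "only" and "open" are said of these compounds alone.

Working notes on the series. For the measured compounds named here, in an assay for inhibition of Fatty-acid amide hydrolase 1 (Rattus norvegicus) (a higher number here means a weaker inhibitor, a lower number a stronger inhibitor), compound 3 `COC(=O)c1ccc(-c2cnc(C(=O)CCc3ccc(-c4ccccc4)cc3)o2)cn1` gives 0.6 nM, the lowest number of the three measured so far. Compound 1 `COC(=O)c1ccc(-c2cnc(C(=O)CCc3ccc(-c4ccccc4)cc3)o2)nc1` gives 2.2 nM in this assay, and compound 2 `O=C(CCc1ccc(-c2ccccc2)cc1)c1ncc(C(=O)C(F)(F)F)o1` gives 8 nM. The measured steps are a 3.7-fold lower number from compound 1 to compound 3 (0.56 log units; beyond the scatter), a 3.6-fold higher number from compound 1 to compound 2 (0.56 log units; beyond the scatter) and a 13-fold lower number from compound 2 to compound 3 (1.12 log units; beyond the scatter); all three concern what sits on the same aromatic carbon of the shared core, and none removes the methoxycarbonyl while keeping the pyridinyl ring. Compound 4 `O=C(CCc1ccc(-c2ccccc2)cc1)c1ncc(-c2cccnc2)o1` differs from compound 3 by hydrogen in place of methoxycarbonyl on an aromatic carbon. The steps from compound 1 and from compound 2 to compound 3 show that the identity of the group on that carbon moves this assay by modest to large amounts, so a loss of part of the best-performing group is expected to cost something, though less than the full exchange seen in a 13-fold lower number from compound 2 to compound 3 (1.12 log units; beyond the scatter). A modest step of a 3.3-fold higher number from compound 3 to compound 4 (0.52 log units; beyond the scatter) is therefore expected, toward a higher number. Compound 4 is estimated at 2 nM, with a range of 0.6 nM to 8 nM.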

Compound 4, inhibition constant: 1.1 nM
Compound 4: middle estimate off by 1.8-fold (0.26 log units), on the high side; the measured number falls inside the stated range.
By their numbers in this assay, from the lowest: compounds 3, 4 and 1 (each within the scatter of the next, the first and the last beyond it); then compound 2.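

In this assay the step of a 1.8-fold higher number from compound 3 to compound 4 (0.26 log units; within the scatter) lies within the scatter, so methoxycarbonyl on this aromatic carbon, next to the ring nitrogen, is not shown to be needed for a low number. The bare pyridin-3-yl keeps most of the separation from the trifluoromethyl ketone, with a 7.3-fold lower number from compound 2 to compound 4 (0.86 log units; beyond the scatter) beyond the scatter, while a 2.0-fold lower number from compound 1 to compound 4 (0.30 log units; within the scatter) stays within it, so compound 4 cannot be told apart from compound 1 or from compound 3 in this assay. No available evidence bears on the reason for this tolerance.

The compounds shown leave open whether a carboxylic acid or a primary amide on the same carbon would stay in this range. They also leave open what a plain phenyl in place of pyridin-3-yl would give.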